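The source may hold more compounds than are shown below. What is called first, only, known or untested is meant among the compounds shown, and "the series" means these compounds.

Measured so far in a functional assay on A549 cells (Homo sapiens) for antiproliferative activity, read by MTT assay, with a stated time of 72 h; a higher number here means a weaker inhibitor, a lower number a stronger inhibitor:
compound 1, `COc1ncc(-c2ccc3nc(NC(=O)NC4CC4)sc3c2)cc1NS(=O)(=O)c1ccc(F)cc1`, giving 900 nM;
compound 2, `COc1ncc(-c2ccc3nc(NC4CC4)sc3c2)cc1NS(=O)(=O)c1ccc(F)cc1`, giving 1330 nM;
compound 3, `O=S(=O)(Nc1cc(-c2ccc3nc(NC4CC4)sc3c2)cnc1Cl)c1ccc(F)cc1`, for which the result is "not determined" (no result reported).

For the measured compounds named here, compound 3 therefore stands nowhere on the numbers: no value for it is available, and no step to it or from it can be drawn. The account follows the change from compound 3 to compound 4, `O=C(Nc1nc2ccc(-c3cnc(Cl)c(NS(=O)(=O)c4ccc(F)cc4)c3)cc2s1)NC1CC1`, which carries the cyclopropylcarbamoyl group of compound 1 on the core of compound 3. The change is cyclopropylcarbamoyl in place of cyclopropyl on a nitrogen on an aromatic ring.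

Going by the values given here, the one measured step that bears on this change is its mirror image, a 1.5-fold higher number from compound 1 to compound 2 (0.17 log units; within the scatter). Read backwards, it suggests that putting cyclopropylcarbamoyl in place of cyclopropyl moves the number little, and not beyond the scatter. With no number for compound 3, the expectation for compound 4 has to rest on compounds 1 and 2 alone and is wide. Compound 4 is expected to give about 900 nM in this assay, within a range from 300 nM to 2700 nM.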

Compound 4, half-maximal inhibitory concentration: 1030 nM
For compound 4 the middle estimate is 1.1-fold (0.06 log units) below the measured one; measured number inside the range.
By their numbers in this assay, from the lowest: compounds 1, 4 and 2 (each within the scatter of the next).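

With the cyclopropylcarbamoyl group held in place, chloro in place of methoxy on an aromatic carbon gives a 1.1-fold higher number from compound 1 to compound 4 (0.06 log units; within the scatter) in this assay, so this position takes either group without a change beyond the scatter. On these data alone, the step from compound 3 to compound 4 cannot be read, and the effect of cyclopropylcarbamoyl in place of cyclopropyl on a nitrogen on an aromatic ring therefore remains untested on the chloro compounds. Nothing given here accounts for the result.

As far as these compounds go, whether this tolerance extends to an amine or a methyl group on that aromatic carbon remains open. So does whether a longer chain in place of the cyclopropyl ring would hold the number in the same range.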